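The source may report more compounds than this note shows. Statements on the series, on what has been measured and on what is new or still open speak of the compounds shown alone.

Measured so far in a functional assay on HL-60 cells (Homo sapiens) for antiproliferative activity, read by MTT assay, with a stated time of 72 h (on this read-out higher numbers stand for weaker inhibition and lower numbers for stronger inhibition), are three compounds:
compound 1 (`CCn1cc(C(=O)O)c(=O)c2cc(F)c(N3CCN(C(=N)NS(=O)(=O)c4ccc(C(F)(F)F)cc4)CC3)cc21`) gives 43 nM
compound 2 (`Cc1ccc(S(=O)(=O)NC(=N)N2CCN(c3cc4c(cc3F)c(=O)c(C(=O)O)cn4C3CC3)CC2)cc1`) gives 43 nM
compound 3 (`CCn1cc(C(=O)O)c(=O)c2cc(F)c(N3CCN(C(=N)NS(=O)(=O)c4cccc(Cl)c4)CC3)cc21`) gives 43 nM

On these numbers compound 3 stands level with compound 1 and compound 2, with nothing separating the three at the digits shown. The next compound, compound 4 (`CCn1cc(C(=O)O)c(=O)c2cc(F)c(N3CCN(C(=N)NS(=O)(=O)c4ccccc4Cl)CC3)cc21`), has the same atoms as compound 3, joined differently: 2-chlorophenyl in place of 3-chlorophenyl on a sulfonyl sulfur.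

Among the compounds with values here, one measured step bears on this change, no change at the digits printed from compound 1 to compound 3 (within the scatter) in the same place, and it lies within the scatter. There, 3-chlorophenyl took the place of 4-(trifluoromethyl)phenyl on a sulfonyl sulfur. Within the data shown here, compound 2 is joined to the others by no single-place step, so it contributes only its level. Among the measured compounds shown here, no measured compound carries 2-chlorophenyl, which leaves this particular change untested and calls for a generous range.

The expectation therefore rests on compound 3 at 43 nM and on the size of no change at the digits printed from compound 1 to compound 3 (within the scatter) alone. In this assay the expected step is a 1.0-fold higher number from compound 3 to compound 4 (0.02 log units; within the scatter) and no move beyond the scatter in either direction is expected. For compound 4 the estimated value is 45 nM with an expected range from 20 nM to 100 nM as the likely span of a measurement.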

Compound 4, half-maximal inhibitory concentration: 43 nM
Compound 4: the middle estimate sits 1.0-fold (0.02 log units) above what was measured; low and high end bracket the measured number.
By their numbers in this assay, from the lowest: compounds 1, 2, 3 and 4 (each within the scatter of the next).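

In this assay, exchanging 3-chlorophenyl for 2-chlorophenyl on a sulfonyl sulfur gave no change at the digits printed from compound 3 to compound 4 (within the scatter), the first direct test at this position of the same substituent placed differently on the phenyl ring. Set against 4-(trifluoromethyl)phenyl, the 2-chlorophenyl group also gave no change at the digits printed from compound 1 to compound 4 (within the scatter), so the three aryl groups carried by compound 1, compound 3 and compound 4 all lie within the scatter of one another, and the earlier single step now has two further steps alongside it. Nothing among the data shown accounts for this unchanged read-out.

The compounds shown all carry an aryl group on the sulfonyl sulfur, so it remains open whether a plain methyl, a longer alkyl chain or a phenyl ring bearing an amine or a carboxylic acid would hold the same level in this assay. On these data alone, it is equally open whether any exchange at this position can move the number at all, since every step read here at this place stays within the scatter.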